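Pyridinylmethyl for Cyanoethyl on a Cyclohexyl Benzamide

The source may hold more compounds than are shown below. What is called first, only, known or untested is meant among the compounds shown, and "the series" means these compounds.

Compound 1 `CN(CCC#N)C(=O)c1ccc([C@H]2[C@@H](F)[C@@H](F)C[C@@H](F)[C@H]2F)cc1` and compound 2 `CN(Cc1cccnc1)C(=O)c1ccc([C@H]2[C@@H](F)[C@@H](F)C[C@@H](F)[C@H]2F)cc1` share one core, while compound 3 `CN(CCC#N)C(=O)c1ccc(C2CCCCC2)cc1` is built on another; the difference between the two cores is not broken down here. In an ADME assay on MDCK-MDR1 cells (Canis lupus familiaris) for permeability, in the apical to basolateral direction, with a stated time of 180 min (a higher number here means that the compound crosses the layer faster, a lower number that the compound crosses the layer more slowly), compound 1 gives 8.1 10^-6 cm/s and compound 2 gives 16.3 10^-6 cm/s. The change between them, (pyridin-3-yl in place of cyanomethyl on a saturated chain carbon bound to an amide-type nitrogen), made a 2.0-fold higher number from compound 1 to compound 2 (0.30 log units; within the scatter). In this assay compound 3 gives 18.7 10^-6 cm/s; its number and that of compound 2 lie within the scatter of each other, whereas compound 1 lies beyond it.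

Compound 4 `CN(Cc1cccnc1)C(=O)c1ccc(C2CCCCC2)cc1` has not yet been measured in this assay. It differs from compound 3 by pyridin-3-yl in place of cyanomethyl on a saturated chain carbon bound to an amide-type nitrogen, the same change, at the same place, that turned compound 1 into compound 2. Because the earlier change produced a 2.0-fold higher number from compound 1 to compound 2 (0.30 log units; within the scatter), a step of comparable size is expected here, a 1.6-fold higher number from compound 3 to compound 4 (0.21 log units; within the scatter), with the caution that a single precedent lies within the scatter. Compound 4 is therefore expected to give about 30 10^-6 cm/s in this assay, with a likely range from 15 10^-6 cm/s to 55 10^-6 cm/s.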

Compound 4, apparent permeability: 12.1 10^-6 cm/s
Compound 4: middle estimate off by 2.5-fold (0.39 log units), on the high side, outside the stated range (below it).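

In this assay, putting (pyridin-3-yl)methyl in place of 2-cyanoethyl on the second core gave a 1.5-fold lower number from compound 3 to compound 4 (0.19 log units; within the scatter), so the step does not keep its direction on this core. Set against the earlier step, the change does not carry over from one core to the other as a fixed increment: the same change on two cores in this assay, a 2.0-fold higher number (0.30 log units; within the scatter) from compound 1 to compound 2 and a 1.5-fold lower number (0.19 log units; within the scatter) from compound 3 to compound 4, 3.1-fold (0.49 log units) apart, beyond the scatter of two such steps. Each step alone lies within the scatter, and with a single pair on each core the data show neither how far the core sets the size of the step nor what the change would do on a third core.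

The compounds shown leave open how other groups would behave at this place on either core, such as a longer nitrile chain, a (pyridin-4-yl)methyl group or an aminoethyl chain. Also open, going by these compounds, is how a core carrying fewer fluorine atoms would respond to the same change.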